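Swapping a lactam for an aminopyrazole: expected lipophilicity

The source may hold more compounds than are shown below. What is called first, only, known or untested is meant among the compounds shown, and "the series" means these compounds.

Measured so far:
- compound 1, `Cc1nccn1-c1cnc(NCc2c(F)ccc3c2CCO3)c2cn[nH]c(=O)c12`: 2.1
- compound 2, `O=C(Nc1cnc(NCc2c(F)ccc3c2CCO3)n2cnnc12)c1ccccc1`: 3
- compound 3, `CC1(C)CC(=O)N(c2cnc(NCc3c(F)ccc4c3CCO4)n3cnnc23)C1`: 2

In a physicochemical assay for lipophilicity, using the shake flask method, in phosphate buffer, measured as octanol-water partition, with a stated time of 30 min, at pH 7.4 (a lower number here means a more polar compound, a higher number a more lipophilic compound), compound 3 gives the lowest of the three numbers; its nearest neighbour is compound 1, within the scatter, while compound 2 lies beyond the scatter above it. Among the compounds with values here, the only measured step, a number 1.00 log units lower from compound 2 to compound 3 (beyond the scatter), exchanged a benzamido for the lactam, which is not the change now made. Compound 4, `CN(c1ccn(C)n1)c1cnc(NCc2c(F)ccc3c2CCO3)n2cnnc12`, differs from compound 3 as follows: methyl(1-methyl-1H-pyrazol-3-yl)amino in place of 4,4-dimethyl-2-oxopyrrolidin-1-yl on an aromatic carbon. Within the data shown here, no measured step bears directly on this exchange, and the two groups match in size. The step of a number 0.30 log units higher from compound 3 to compound 4 (within the scatter) is therefore expected to stay within the scatter. Compound 4 is estimated at 2.3 in this assay, between 1.7 and 2.9.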

Compound 4, distribution coefficient: 1.8
Compound 4: the middle estimate sits 0.50 log units above what was measured; low and high end bracket the measured number.
By their numbers in this assay, from the lowest: compounds 4, 3 and 1 (each within the scatter of the next); then compound 2.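

In this assay the step of a number 0.20 log units lower from compound 3 to compound 4 (within the scatter) shows that, on this aromatic carbon, a five-membered aromatic ring with 2 hetero atoms in methyl(1-methyl-1H-pyrazol-3-yl)amino can replace the non-aromatic ring of 4,4-dimethyl-2-oxopyrrolidin-1-yl with no readable change. The step of a number 1.20 log units lower from compound 2 to compound 4 (beyond the scatter) shows that benzamido now stands apart from two different groups at this position. Nothing measured here offers a reason for these numbers. 

From the compounds shown here alone, whether a small amine such as dimethylamino, or a carboxylic acid, would fall with these two groups or with benzamido stays open.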